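Urea analogue of compound 3 in the cell growth series

The source may hold more compounds than are shown below. What is called first, only, known or untested is meant among the compounds shown, and "the series" means these compounds.

Measured compounds:
compound 1 `COc1cc(-c2nn(-c3cccc(NC(=O)c4cccc(C(F)(F)F)c4)c3)cc2-c2ccncc2)ccc1Cl` — in a functional assay on SN12C cells (Homo sapiens) for inhibition, read by sulforhodamine B assay, with a stated time of 48 h (on this read-out higher numbers stand for weaker inhibition of growth and lower numbers for stronger inhibition of growth), compound 1 gives > 50000 nM, a limit of the assay.
compound 2 `COc1cc(-c2nn(-c3cccc(NC(=O)Nc4ccc(Cl)c(Cl)c4)c3)cc2-c2ccncc2)ccc1Cl` — in this assay compound 2 gives > 50000 nM, a limit of the assay.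
compound 3 `COc1cc(-c2nn(-c3cccc(NC(=O)c4ccc(Cl)c(C(F)(F)F)c4)c3)cc2-c2ccncc2)ccc1Cl` — in this assay compound 3 gives > 32500 nM, a limit of the assay.

Compound 3 stands at the limit of > 32500 nM in this assay, at which 1 of the 3 values shown sits. Compound 1 and compound 2 sit at the limit of > 50000 nM in this assay, at which 2 of the 3 values shown sit. No order among the three can be read from such limits.

Compound 4 `COc1cc(-c2nn(-c3cccc(NC(=O)Nc4ccc(Cl)c(C(F)(F)F)c4)c3)cc2-c2ccncc2)ccc1Cl` differs from compound 3 by (4-chloro-3-(trifluoromethyl)phenyl)amino in place of 4-chloro-3-(trifluoromethyl)phenyl on a carbonyl carbon. For the measured compounds named here, the steps that bear on this change are a step that the two limits leave unreadable from compound 2 to compound 3 and a step that the two limits leave unreadable from compound 1 to compound 2, and a step that the two limits leave unreadable from compound 1 to compound 3 is no more readable. In this assay, going by the values given here, no step of any readable size is therefore expected from compound 3 to compound 4, and compound 4 is expected to return a limit again. The estimate for compound 4 is 50000 nM, in the range 15000 nM to 100000 nM, which means an expected step that the limit leaves unreadable from compound 3 to compound 4.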

Compound 4, concentration for total growth inhibition: 9230 nM
The estimate for compound 4 lay 5.4-fold (0.73 log units) above the measured number; measured number outside the range, below it.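

In this assay, (4-chloro-3-(trifluoromethyl)phenyl)amino in place of 4-chloro-3-(trifluoromethyl)phenyl on the carbonyl carbon gives an at least 3.5-fold lower number from compound 3 to compound 4 (0.54 log units; beyond the scatter). With the carbonyl carbon still bearing an amino-linked aryl group, trifluoromethyl in place of chloro gives an at least 5.4-fold lower number from compound 2 to compound 4 (0.73 log units; beyond the scatter), and the change that adds both the amino link and the chloro gives an at least 5.4-fold lower number from compound 1 to compound 4 (0.73 log units; beyond the scatter). Compound 4 is the only one of the four with a number and not a limit, and the steps among the other three cannot be read.

Going by these compounds, whether a nitrile or a methyl in place of trifluoromethyl on an aromatic carbon would hold this level stays open. Nothing measured here bears on why the number falls.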